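The compounds below may be only part of what the source reports. "The series", "measured", "known", "first", "only" and "open" are said of these compounds alone.

All three measured compounds were tested in an ADME assay on HEK293 cells (Homo sapiens) for cytotoxicity, read by sulforhodamine B assay, with a stated time of 48 h, tested at 10 uM; a higher number here means more inhibition at the concentration tested (going by the name of the read-out), a lower number less inhibition:

Compound 1, `COc1nc2ccc(Br)cc2cc1C(c1ccccc1)n1cc(-c2ccccc2)nn1`, gives 8.25%.
Compound 2, `COc1nc2ccc(Br)cc2cc1C(c1ccccc1)n1cc(-c2ccccc2F)nn1`, gives 3.97%.
Compound 3, `CCCc1cn(C(c2ccccc2)c2cc3cc(Br)ccc3nc2OC)nn1`, gives 0.85%.

Compound 2 lies within the scatter of both others: a number 4.3 percentage points lower from compound 1 to compound 2 (within the scatter) and a number 3.1 percentage points lower from compound 2 to compound 3 (within the scatter). Compound 4, `COc1nc2ccc(Br)cc2cc1C(c1ccccc1)n1cc(CCO)nn1`, differs from compound 2 by one change: 2-hydroxyethyl in place of 2-fluorophenyl on an aromatic carbon. For the measured compounds named here, the step that bears on it most is the one from compound 2 to compound 3, where a chain also took the place of 2-fluorophenyl, and the step from compound 1 to compound 3, a number 7.4 percentage points lower from compound 1 to compound 3 (within the scatter), tells the same: neither left the scatter. No step beyond the scatter is therefore expected in this assay. Compound 4 is expected to give 3%, with a range from -5% to 12%. The expected step of a number 1 percentage points lower from compound 2 to compound 4 (within the scatter) stays within the scatter.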

Compound 4, a percentage reported as inhibition, at one concentration (the size of the read-out at that concentration, not a potency): 4.54%
Compound 4: middle estimate off by 1.5 percentage points, on the low side, and the stated range covers the measured number.
By their numbers in this assay, from the lowest: compounds 3, 2, 4 and 1 (each within the scatter of the next).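

In this assay, for the compounds shown here, the earlier compounds carried only carbon groups with no hydrogen-bond donor or acceptor at this aromatic carbon, whereas 2-hydroxyethyl brings both and still gives a number 0.6 percentage points higher from compound 2 to compound 4 (within the scatter). The other two comparisons agree, with a number 3.7 percentage points higher from compound 3 to compound 4 (within the scatter) for hydroxy in place of methyl and a number 3.7 percentage points lower from compound 1 to compound 4 (within the scatter) for 2-hydroxyethyl in place of phenyl, so neither the ring nor the hydroxy separates these compounds here. No measurement shown explains this result. On these data alone, whether an amine or a carboxylic acid at this position would step beyond the scatter stays open.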